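Iodovinyl for methyl on the ring amine of compound 2

A few compounds are considered here, and "the series" means these few. Any claim that something is new, unique, unknown or untested is made for them only; others in the source may bear on it.

Compound 1: `OC1CN(Cc2cccc(Br)c2)CCC1N1CCN(c2ccccc2)CC1` — 66 nM
Compound 2: `CCN1CCC(O)C(N2CCN(c3ccccc3)CC2)C1` — > 1000 nM

Of the compounds shown here, two have been measured in an assay on PC-12 cells for displacement of a labelled ligand from vesicular acetylcholine transporter (Homo sapiens); a higher number here means a weaker inhibitor, a lower number a stronger inhibitor. Compound 1, `OC1CN(Cc2cccc(Br)c2)CCC1N1CCN(c2ccccc2)CC1`, gives 66 nM. Compound 2, `CCN1CCC(O)C(N2CCN(c3ccccc3)CC2)C1`, is recorded only as a limit, > 1000 nM, and sits at the limit of > 1000 nM in this assay, at which 1 of the 2 values shown sits. Compound 3, `OC1CCN(C/C=C/I)CC1N1CCN(c2ccccc2)CC1`, has not yet been measured. It differs from compound 2 in one place: 2-iodoethenyl in place of methyl on a saturated chain carbon bound to an amine nitrogen in a ring. For the measured compounds named here, no step between measured compounds is available, so the size of the change cannot be read from the data. On the strength of compound 1 at 66 nM, the expectation is a move toward stronger inhibition, that is the step from compound 2 to compound 3 is estimated as an at least 4.0-fold lower number from compound 2 to compound 3 (0.60 log units; beyond the scatter). Compound 3 is therefore expected to give about 250 nM, with a range from 40 nM to 2000 nM.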

Compound 3, half-maximal inhibitory concentration: > 100 nM
Compound 3 gave a limit, no number; the forecaster's own chance of this, stated with the estimate: 25%; the middle value is on the limit's open side.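

In this assay, for the compounds shown here, compound 2 and compound 3 are each recorded only as a limit, and no step between the two can be read. The compounds shown leave open whether 2-iodoethenyl in place of methyl gives a stronger or a weaker inhibitor, or neither.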